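Benzyl-for-diol swap at the chain on the shared core

The source may report more compounds than this note shows. Statements on the series, on what has been measured and on what is new or still open speak of the compounds shown alone.

Measured so far:
compound 1 `Nc1nc(O)c2c(n1)n(C1OC(CO)[C@@H](O)[C@H]1O)c(=O)n2CC(O)CO` — 136%
compound 2 `C=CCn1c(=O)n(C2OC(CO[Si](C)(C)C(C)(C)C)[C@@H](O)[C@H]2O)c2nc(N)nc(O)c21` — 5%

In a functional assay on the whole organism (B cells) with Mus musculus as the target (on this read-out lower numbers stand for smaller maximal responses and higher numbers for larger maximal responses), compound 1 holds the highest of the two numbers; compound 2 sits far lower, a gap beyond the scatter, though compound 2 also carries a different sugar protection, so its two values alone are noted. Compound 3 `Nc1nc(O)c2c(n1)n(C1OC(CO)[C@@H](O)[C@H]1O)c(=O)n2Cc1ccc([N+](=O)[O-])cc1` carries 4-nitrophenyl in place of 1,2-dihydroxyethyl on a saturated chain carbon bound to an aromatic nitrogen. Going by the values given here, no comparable single step has been measured. The expectation for a number 76 percentage points lower from compound 1 to compound 3 (beyond the scatter) is a decrease beyond the scatter, since the only other nitrogen substituent measured, compound 2 with 5%, gives a small maximal response. Compound 3 is therefore estimated at 60%, with a range of 5% to 140%.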

Compound 3, largest response reached (reported as maximal response), in percent of the reference or control that the assay uses: 147%
The estimate for compound 3 lay 87 percentage points below the measured number; the whole stated range lies below it.
By their numbers in this assay, from the lowest: compound 2; then compound 1; then compound 3.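

Replacing 1,2-dihydroxyethyl with 4-nitrophenyl on a saturated chain carbon bound to an aromatic nitrogen gives a number 11 percentage points higher from compound 1 to compound 3 (beyond the scatter) in this assay, a modest step. The maximal response at this position therefore does not depend on the 2 hydrogen-bond donors of the leaving group, and the position accepts a six-membered aromatic ring. Nothing available bears on the reason for this step.

Going by these compounds, it remains open whether the response follows the ring or the nitro group. A plain benzyl, a 4-aminobenzyl or a 4-carboxybenzyl on the shared core would separate the two.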